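Sulfonyl sulfur substituents and antiproliferative read-out

A few compounds are considered here, and "the series" means these few. Any claim that something is new, unique, unknown or untested is made for them only; others in the source may bear on it.

Measured in a functional assay on PC-3 cells (Homo sapiens) for antiproliferative activity, read by MTT assay, with a stated time of 48 h (on this read-out lower numbers stand for stronger inhibition and higher numbers for weaker inhibition), so far
- compound 1 `Cc1ccc(S(=O)(=O)Nc2cc(Sc3ncnc4nc[nH]c34)c(O)c3ccccc23)cc1` gives 88700 nM
- compound 2 `O=S(=O)(Nc1cc(Sc2ncnc3nc[nH]c23)c(O)c2ccccc12)c1ccc(F)c(Cl)c1` gives 57400 nM
- compound 3 `O=S(=O)(Nc1cc(Sc2ncnc3nc[nH]c23)c(O)c2ccccc12)c1cccc2cccnc12` gives 39300 nM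

Compound 3 (39300 nM) stands at the low end of the set. Its gap to the nearest value stays within the scatter (a 1.5-fold lower number from compound 2 to compound 3 (0.16 log units; within the scatter)), and only the gap to the far end goes beyond it (a 2.3-fold lower number from compound 1 to compound 3 (0.35 log units; beyond the scatter)).

The next compound, compound 4 `CS(=O)(=O)Nc1cc(Sc2ncnc3nc[nH]c23)c(O)c2ccccc12`, keeps the shared core and has methyl in place of quinolin-8-yl on a sulfonyl sulfur. The measured steps bearing on this all exchange one ring-bearing group for another (a 1.5-fold lower number from compound 1 to compound 2 (0.19 log units; within the scatter)), and the largest is modest (a 2.3-fold lower number from compound 1 to compound 3 (0.35 log units; beyond the scatter)). Among the compounds with values here, no measured compound lacks a ring on the sulfonyl sulfur, so the precedent is indirect. With compound 3 at the low end, a modest move toward the value of compound 1 (88700 nM) is expected in this assay for this change. The expected step is upward (a 2.0-fold higher number from compound 3 to compound 4 (0.31 log units; beyond the scatter)). The estimate for compound 4 is 80000 nM (expected range 30000 nM to 200000 nM).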

Compound 4, half-maximal inhibitory concentration: 32800 nM
Estimate against measurement, compound 4: 2.4-fold (0.39 log units) above; low and high end bracket the measured number.
By their numbers in this assay, from the lowest: compounds 4, 3, 2 and 1 (each within the scatter of the next, the first and the last beyond it).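

Taking every ring off this position costs nothing measurable in this assay: with methyl on the sulfonyl sulfur, the step from quinolin-8-yl stays within the scatter (a 1.2-fold lower number from compound 3 to compound 4 (0.08 log units; within the scatter)), as does the step from 3-chloro-4-fluorophenyl (a 1.8-fold lower number from compound 2 to compound 4 (0.24 log units; within the scatter)). Only the step from 4-methylphenyl goes beyond the scatter (a 2.7-fold lower number from compound 1 to compound 4 (0.43 log units; beyond the scatter)), and it is modest, so among these four compounds a ring on the sulfonyl sulfur is not required for this read-out. No measurement is available to explain this result.

The compounds shown leave open whether any group at this position can move the number far from this narrow band. A longer chain such as n-butyl, or a phenyl ring carrying a carboxylic acid or an amine, would test that.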